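The compounds below may be only part of what the source reports. "The series", "measured", "known", "first", "only" and "open" are said of these compounds alone.

Compound 1, `Cc1noc2c1N=C(c1ccc(Cl)cc1)CC(c1ccccc1)C2C(c1ccccc1)C1c2onc(C)c2N=C(c2ccc(Cl)cc2)CC1c1ccccc1`, gives 60.2 ug/mL.
Compound 2, `Cc1noc2c1N=C(c1ccccc1)CC(c1ccccc1)C2C(c1ccccc1)C1c2onc(C)c2N=C(c2ccccc2)CC1c1ccccc1`, gives 68.7 ug/mL.

Both numbers come from a functional assay on HeLa cells (Homo sapiens) for cytotoxicity, read by MTT assay, with a stated time of 48 h (on this read-out lower numbers stand for stronger inhibition and higher numbers for weaker inhibition), where a compound that kills cells at a small amount gives a low number. Compound 1 and compound 2 stand apart by far less than the usual scatter of this assay, so the two values show the same weak effect and no order between them can be read. Compound 3, `COc1ccc(C(C2c3onc(C)c3N=C(c3ccccc3)CC2c2ccccc2)C2c3onc(C)c3N=C(c3ccccc3)CC2c2ccccc2)cc1`, differs from compound 2 in one place only: methoxy in place of hydrogen on an aromatic carbon. Seen one bond further out, a phenyl becomes a 4-methoxyphenyl. Within the data shown here, with only two measured compounds, both weak and alike, there is no measured step to lean on. The step of a 1.1-fold lower number from compound 2 to compound 3 (0.04 log units; within the scatter) is expected to stay within the scatter, in no clear direction. Compound 3 is therefore expected to give about 62 ug/mL, most likely between 30 ug/mL and 125 ug/mL.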

Compound 3, half-maximal inhibitory concentration: 65.9 ug/mL
Beside the measured number, compound 3's estimate is 1.1-fold (0.03 log units) below it; low and high end bracket the measured number.
By their numbers in this assay, from the lowest: compounds 1, 3 and 2 (each within the scatter of the next).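

In this assay, turning the phenyl into a 4-methoxyphenyl gives a 1.0-fold lower number from compound 2 to compound 3 (0.02 log units; within the scatter), so the change makes no readable difference to this weak cytotoxicity. Among these compounds, this is the first measured step at this position, on an aromatic carbon para to a large group, and it shows that a methoxy group, with its two heavy atoms and one hydrogen-bond acceptor, can stand in place of hydrogen here without a readable change in the number. No other data are available that could give a reason for this result.

On these data alone, it remains open whether an amine, a carboxylic acid or a longer chain such as butoxy at the same place would move the number beyond the scatter. It is also unknown whether any group here could give markedly stronger cell killing than these compounds show.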